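Compound 4: an estimate from three measured neighbours

The compounds below may be only part of what the source reports. "The series", "measured", "known", "first", "only" and "open" are said of these compounds alone.

Values in an ADME assay on WI-38 cells (Homo sapiens) for cytotoxicity, read by MTT assay, with a stated time of 72 h; on this read-out higher numbers stand for weaker inhibition and lower numbers for stronger inhibition:
Compound 1 `O=C(CCc1cccc2c1B(O)OC2)Nc1ccc(Br)cc1`: 42000 nM
Compound 2 `O=C(CCc1cccc2c1B(O)OC2)Nc1ccc(I)cc1`: 49000 nM
Compound 3 `COc1ccc(NC(=O)CCc2cccc3c2B(O)OC3)cc1`: > 100000 nM, a limit

In this assay compound 3 stands at > 100000 nM, which is a limit of the assay and not a number. Compound 4 `CC(C)(C)OC(=O)NCc1ccc(NC(=O)CCc2cccc3c2B(O)OC3)cc1` carries ((tert-butoxycarbonyl)amino)methyl in place of methoxy on an aromatic carbon. Among the measured compounds shown here, no measured step makes this exact change. The nearest steps exchange the group on that same carbon: methoxy for bromo gave an at least 2.3-fold higher number from compound 1 to compound 3 (0.37 log units; beyond the scatter), methoxy for iodo gave an at least 2.0-fold higher number from compound 2 to compound 3 (0.30 log units; that floor lies within the scatter), and iodo for bromo gave a 1.2-fold higher number from compound 1 to compound 2 (0.07 log units; within the scatter). These steps are small, so a modestly lower number, or no change beyond the scatter, is expected. The estimated step is an at least 1.4-fold lower number from compound 3 to compound 4 (0.15 log units; that floor lies within the scatter). For compound 4 the estimated value is 70000 nM, with an expected range of 30000 nM to 100000 nM.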

Compound 4, half-maximal inhibitory concentration: 4800 nM
Beside the measured number, compound 4's estimate is 15-fold (1.16 log units) above it; the measured number lies below the stated range.
By their numbers in this assay, from the lowest: compound 4; then compounds 1 and 2 (each within the scatter of the next). At a limit, above all of these: compound 3.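

In this assay, this aromatic carbon, para to a large group, proves far more responsive than the exchanges among bromo, iodo and methoxy showed: ((tert-butoxycarbonyl)amino)methyl gives an 8.8-fold lower number from compound 1 to compound 4 (0.94 log units; beyond the scatter) and a 10-fold lower number from compound 2 to compound 4 (1.01 log units; beyond the scatter). Against methoxy, the change gives an at least 20-fold lower number from compound 3 to compound 4 (1.31 log units; beyond the scatter). Compound 3 stands at a limit of the assay and not at a number, so that step is only a floor: the limit of > 100000 nM in this assay, at which 1 of the 4 values shown sits.

The compounds shown leave open which part of the entering group matters. A free aminomethyl group or a carboxylic acid on the same carbon would begin to separate these parts.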